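The source may report more compounds than this note shows. Statements on the series, on what has been measured and on what is new or still open speak of the compounds shown alone.

Of the compounds shown here, two have so far been tested in an ADME assay (liver) for metabolic stability, with Liver microsome (Rattus norvegicus) as the target, using microsomes and NADPH, with a stated time of 30 min, at 37 degrees C, tested at 1 uM; a lower number here means slower removal, a higher number faster removal of the compound. Compound 1 (`Nc1ccc(S(=O)(=O)c2ccc(-c3ncc(C(O)(C(F)(F)F)C(F)(F)F)cc3Cl)cc2)cn1`) gives 18 mL.min-1.g-1, and compound 2 (`CCNc1nc(S(=O)(=O)c2ccc(N)nc2)ccc1-c1ccc(C(C)(O)C(F)(F)F)cn1`) gives 42 mL.min-1.g-1. Compound 2 thus holds the higher of the two numbers, and its gap to compound 1 lies beyond the usual scatter of repeated measurements. The two differ in more than one place, so that gap cannot be read as the result of any single change.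

Compound 3 (`CC(O)(c1ccc(-c2ccc(S(=O)(=O)c3ccc(N)nc3)nc2NC2CC2)nc1)C(F)(F)F`) has not yet been measured. It carries cyclopropyl in place of ethyl on a nitrogen on an aromatic ring, a change from ethylamino to cyclopropylamino: cyclopropyl in place of ethyl on a nitrogen on an aromatic ring. Among the compounds with values here, no measured pair differing in one place shows how large such a step might be, so the expectation starts from compound 2 at 42 mL.min-1.g-1. No shift beyond the scatter is expected in this assay, with only a slight lean towards a lower number. The expected 1.2-fold lower number from compound 2 to compound 3 (0.08 log units; within the scatter) therefore stays within the scatter. For compound 3 the estimated value is 35 mL.min-1.g-1, with an expected range of 18 mL.min-1.g-1 to 70 mL.min-1.g-1.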

Compound 3, intrinsic clearance in microsomes: 43 mL.min-1.g-1
Beside the measured number, compound 3's estimate is 1.2-fold (0.09 log units) below it, and the stated range covers the measured number.
By their numbers in this assay, from the lowest: compound 1; then compounds 2 and 3 (each within the scatter of the next).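

Within the data shown here, the pair of compound 2 and compound 3 gives the first reading of a change at a single place, and in this assay it shows a 1.0-fold higher number from compound 2 to compound 3 (0.01 log units; within the scatter) for the exchange of ethylamino for cyclopropylamino. On a nitrogen on an aromatic ring, then, cyclopropyl in place of ethyl brings one more carbon and a three-membered ring, yet the two compounds cannot be told apart in intrinsic clearance in microsomes, at least for this one pair on this one core. Nothing measured here explains why the two compounds read alike.

The compounds shown leave open whether other groups on that same nitrogen, such as a propyl or other longer chain, a cyclobutyl ring or a methoxyethyl chain, would also stay within the scatter of compound 2, or whether ethyl and cyclopropyl simply happen to match. Among these compounds, they also leave open whether the same exchange of ethyl for cyclopropyl would read alike on a different core, since this single pair is the only step available at this place.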